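Methoxy replacing chloro on the oxindole ring

The compounds below may be only part of what the source reports. "The series", "measured", "known", "first", "only" and "open" are said of these compounds alone.

The set is three measured compounds and one to come. Compound 1 `COc1c(/C=C2/C(=O)Nc3ccccc32)c2ccccc2n1-c1ccccc1` gives 1380 nM in a functional assay on cells (Cancer cell lines, Homo sapiens) for cytotoxicity, with a stated time of 48 h; a lower number here means a stronger inhibitor of growth, a higher number a weaker inhibitor of growth. Compound 2 `COc1c(/C=C2/C(=O)Nc3ccc(Cl)cc32)c2ccccc2n1-c1ccccc1` gives 8510 nM, and compound 3 `O=C1Nc2ccc(Cl)cc2/C1=C\c1c(Cl)n(CCCc2ccccc2)c2ccccc12` gives 2450 nM. Compound 2 therefore stands highest of the three in this assay, with compound 3 nearest and compound 1 furthest.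

For the measured compounds named here, the one measured step that touches the same position is a 6.2-fold higher number from compound 1 to compound 2 (0.79 log units; beyond the scatter), which shows that putting chloro in place of hydrogen on that aromatic carbon weakened growth inhibition. Compound 3 carries other changes elsewhere as well, so its number cannot be read as a step against compound 2.

Compound 4 `COc1ccc2c(c1)/C(=C\c1c(OC)n(-c3ccccc3)c3ccccc13)C(=O)N2` differs from compound 2 by methoxy in place of chloro on an aromatic carbon. Going by the values given here, no measured pair shows methoxy against chloro at this site, so the direction is uncertain: methoxy could behave like the hydrogen of compound 1 or like the chloro of compound 2. Compound 4 is expected to land between those two, estimated at 4000 nM with a likely range of 1200 nM to 12000 nM, which means an expected step of a 2.1-fold lower number from compound 2 to compound 4 (0.33 log units; beyond the scatter) in this assay.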

Compound 4, concentration for 50% growth inhibition: 2000 nM
Beside the measured number, compound 4's estimate is 2.0-fold (0.30 log units) above it; the range from low to high includes it.
By their numbers in this assay, from the lowest: compounds 1, 4 and 3 (each within the scatter of the next); then compound 2.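

In this assay, methoxy in place of chloro on this aromatic carbon gives a 4.3-fold lower number from compound 2 to compound 4 (0.63 log units; beyond the scatter), so the weaker growth inhibition that came with chloro does not follow from every group placed at this position. Set against the unsubstituted parent, methoxy in place of hydrogen gives a 1.4-fold higher number from compound 1 to compound 4 (0.16 log units; within the scatter), which lies within the scatter, so among the three groups seen at this carbon, chloro alone stands apart, while methoxy, with two heavy atoms and one hydrogen-bond acceptor, cannot be told from hydrogen. The information given offers nothing that accounts for this difference between chloro and methoxy.

The compounds shown leave open whether other groups on this carbon, such as an amine, a carboxylic acid or a longer ether chain like ethoxy, would stay level with hydrogen and methoxy or rise towards chloro. They also leave open whether methoxy in place of chloro would give a similar step on the core of compound 3, which differs from compound 2 in other places as well.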